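The source may hold more compounds than are shown below. What is called first, only, known or untested is meant among the compounds shown, and "the series" means these compounds.

Compound 2 `CO[C@H]1CC[C@H](CN2CC(=O)Nc3ncc(-c4ccc(C(C)(C)O)nc4)nc32)CC1` gives 77% in an ADME assay on S9 fraction (Rattus norvegicus) for metabolic stability, with a stated time of 60 min (on this read-out higher numbers stand for a more stable compound and lower numbers for a less stable compound), and stands lowest of the two measured numbers, with compound 1 `CO[C@H]1CC[C@H](N2CC(=O)Nc3ncc(-c4ccc(C(C)(C)O)nc4)nc32)CC1` giving 94% and the step of a number 17 percentage points lower from compound 1 to compound 2 (beyond the scatter) lying beyond the scatter. Compound 3 `CC(C)(O)c1ccc(-c2cnc3c(n2)N(CC2CCCCC2)CC(=O)N3)cn1` differs from compound 2 by hydrogen in place of methoxy on a saturated ring carbon. Within the data shown here, no measured step removes a methoxy, and the step from compound 1 to compound 2 concerns a different change, so no direction is grounded in what has been measured. For compound 3 a step of a number 2 percentage points lower from compound 2 to compound 3 (within the scatter) is expected, within the scatter. Compound 3 is therefore estimated at 75%, between 50% and 92%.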

Compound 3, percent of the compound remaining: 16%
Compound 3: the middle estimate sits 59 percentage points above what was measured; measured number below the stated range.
By their numbers in this assay, from the lowest: compound 3; then compound 2; then compound 1.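

Among these compounds, with the methoxy on the saturated ring carbon replaced by hydrogen, this assay shows a number 61 percentage points lower from compound 2 to compound 3 (beyond the scatter); the earlier compounds all carried this methoxy, so only this result reveals how much the read-out depends on it. Cyclohexylmethyl in place of 4-methoxycyclohexyl gives a number 78 percentage points lower from compound 1 to compound 3 (beyond the scatter), the widest gap among the three compounds. No measurement here gives a cause for these drops. From the compounds shown here alone, whether another group at this place, such as a hydroxyl or an amine, would match methoxy remains open. So does the effect of losing methoxy when cyclohexyl sits directly on the nitrogen.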